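The compounds below may be only part of what the source reports. "The series", "measured", "known", "first", "only" and "open" are said of these compounds alone.

In an ADME assay on liver for metabolic stability, with Liver microsome (Homo sapiens) as the target, using microsomes (on this read-out higher numbers stand for fast clearance and lower numbers for slow clearance), compound 1 `CCN(CC)CCN(C)c1ccc(Nc2cc(NC3CC3)n3ncc(C#N)c3n2)cc1NC(C)=O` gives 44 mL.min-1.g-1 and compound 2 `CC(=O)Nc1cc(Nc2cc(NC3CC3)n3ncc(C#N)c3n2)ccc1N1CCC[C@@H](N(C)C)C1` gives 19 mL.min-1.g-1, the lower of the two numbers. Next, compound 3 `CC(=O)Nc1cc(Nc2cc(NC3CC3)n3ncc(C#N)c3n2)ccc1N1CC[C@H](N)C1` alters the group on the aromatic carbon ortho to the acetamido group: a group of 6 heavy atoms (4 carbon, 2 nitrogen; one five-membered non-aromatic ring with 1 hetero atom) in place of a group of 9 heavy atoms (7 carbon, 2 nitrogen; one six-membered non-aromatic ring with 1 hetero atom), on an aromatic carbon. Within the data shown here, the only measured step at this place, a 2.3-fold lower number from compound 1 to compound 2 (0.36 log units; beyond the scatter), was modest and put a six-membered non-aromatic ring in place of a group with no ring, so it is a loose guide. Among the measured compounds shown here, with only that step to go on, no change beyond the scatter is expected, a 1.3-fold lower number from compound 2 to compound 3 (0.10 log units; within the scatter). For compound 3 the estimate is 15 mL.min-1.g-1, with an expected range from 7 mL.min-1.g-1 to 32 mL.min-1.g-1.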

Compound 3, intrinsic clearance in microsomes in the Liver microsome assay: < 3 mL.min-1.g-1
Compound 3 ended at the assay's limit; the forecaster's own chance of this, stated with the estimate: 8%; at least 5.0-fold (0.69 log units) between middle value and limit.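

At this position, the group on the aromatic carbon can matter much more than the first step suggested: in the Liver microsome assay, compound 3 gives < 3 mL.min-1.g-1, a limit of the assay, and 3-aminopyrrolidin-1-yl brings an at least 6.3-fold lower number from compound 2 to compound 3 (0.80 log units; beyond the scatter) and also an at least 14-fold lower number from compound 1 to compound 3 (1.16 log units; beyond the scatter). The value of compound 3 is a limit, so both steps are minimums: the limit of < 3 mL.min-1.g-1 in the Liver microsome assay, at which 1 of the 3 values shown sits.

In a physicochemical assay for solubility, read by LC-MS, in phosphate buffer, with a stated time of 24 h, at pH 7.4 (a higher number here means a more soluble compound, a lower number a less soluble compound), compound 2 gives > 900000 nM, which is a limit of the assay: the limit of > 900000 nM in the physicochemical assay, at which 1 of the 2 values shown sits. In the physicochemical assay, compound 3 gives 590000 nM.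

The ring size and the amine group change together in these steps, and the compounds shown do not separate the two. A 3-aminopiperidin-1-yl group, or a 3-(dimethylamino)pyrrolidin-1-yl group, at this position would tell them apart.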